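Replacing Trifluoromethyl with a Hydroxyalkyl Group on Compound 1

The compounds below may be only part of what the source reports. "The series", "measured", "known", "first", "only" and "open" are said of these compounds alone.

Compound 1 `FC(F)(F)c1ccccc1-c1ccc2[nH]c(C3=NOC4(CCCCC4)C3)nc2c1`: 3.1 nM
Compound 2 `N#Cc1cc(-c2ccccc2C(F)(F)F)cc2nc(C3=NOC4(CCCCC4)C3)[nH]c12`: 0.7 nM
Compound 3 `FC(F)(F)c1ccccc1-c1cc(Br)c2[nH]c(C3=NOC4(CCCCC4)C3)nc2c1`: 2.7 nM

In a functional assay on HEK293 cells for antagonist activity at transient receptor potential M8 protein (Canis lupus familiaris), read by FLIPR and calcium flux (on this read-out higher numbers stand for weaker inhibition and lower numbers for stronger inhibition), compound 1 gives the highest number of the three. Compound 3 lies within the scatter of it (a 1.1-fold lower number from compound 1 to compound 3 (0.06 log units; within the scatter)), whereas compound 2 shows a 4.4-fold lower number from compound 1 to compound 2 (0.65 log units; beyond the scatter). Compound 4 `CC(C)(O)c1ccccc1-c1ccc2[nH]c(C3=NOC4(CCCCC4)C3)nc2c1` differs from compound 1 by 1-hydroxy-1-methylethyl in place of trifluoromethyl on an aromatic carbon. Within the data shown here, none of the measured steps bears on this change: both alter the shared core, leaving the trifluoromethyl untouched, so there is no direct guide. Because compound 1 gives 3.1 nM, a modest weakening is expected, a 4.8-fold higher number from compound 1 to compound 4 (0.68 log units; beyond the scatter), with wide uncertainty since the change introduces a hydrogen-bond donor where none stood before. Compound 4 is estimated at 15 nM, between 3 nM and 80 nM.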

Compound 4, half-maximal inhibitory concentration: 7.9 nM
The estimate for compound 4 lay 1.9-fold (0.28 log units) above the measured number; the measured number falls inside the stated range.
By their numbers in this assay, from the lowest: compound 2; then compounds 3 and 1 (each within the scatter of the next); then compound 4.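

In this assay, swapping the trifluoromethyl on this aromatic carbon for 1-hydroxy-1-methylethyl weakens inhibition only modestly, a 2.5-fold higher number from compound 1 to compound 4 (0.41 log units; beyond the scatter). Among these compounds, the earlier compounds changed only the shared core, so this is the first sign that this position can take a group with a hydrogen-bond donor and acceptor and still keep much of its inhibition. No measurement shown explains the shift. Still open, from the compounds shown here alone, is how an amine or a carboxylic acid would fare at this position, and whether adding the cyano group of compound 2 to compound 4 would strengthen inhibition.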